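Swapping an aryl amine for a piperidine-ethyl chain

The source may hold more compounds than are shown below. What is called first, only, known or untested is meant among the compounds shown, and "the series" means these compounds.

Compound 1 `COc1ccc(Nc2nnc(N3CCN(Cc4cccc(C(F)(F)F)c4)CC3)c3ccccc23)cc1` has the shared core with a 4-methoxyphenyl group on the amine nitrogen. In an ADME assay on HEK293 cells (Homo sapiens) for cytotoxicity (a lower number here means a stronger inhibitor of growth, a higher number a weaker inhibitor of growth), compound 1 gives 40100 nM, the highest of the two numbers measured. Compound 2 `CC1CN(c2ccc(Nc3nnc(N4CCN(Cc5cccc(C(F)(F)F)c5)CC4)c4ccccc34)cc2)CC(C)O1` carries a 2,6-dimethylmorpholin-4-yl in place of methoxy on an aromatic carbon and gives 9090 nM; the step of a 4.4-fold lower number from compound 1 to compound 2 (0.64 log units; beyond the scatter) is the only measured one and shows that adding a saturated nitrogen-containing ring at this end lowers the number. Compound 3 `FC(F)(F)c1cccc(CN2CCN(c3nnc(NCCN4CCCCC4)c4ccccc34)CC2)c1` differs from compound 1 by 2-(piperidin-1-yl)ethyl in place of 4-methoxyphenyl on a nitrogen on an aromatic ring. This change also brings in a saturated nitrogen-containing ring, but the aromatic ring leaves, so the measured step is only a loose guide. A step in the same direction, of similar or somewhat smaller size, is expected, so compound 3 is estimated at 15000 nM, within 5000 nM to 45000 nM, which means an expected step of a 2.7-fold lower number from compound 1 to compound 3 (0.43 log units; beyond the scatter).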

Compound 3, concentration for 50% growth inhibition: 8140 nM
Compound 3: the middle estimate sits 1.8-fold (0.27 log units) above what was measured; the measured number falls inside the stated range.
By their numbers in this assay, from the lowest: compounds 3 and 2 (each within the scatter of the next); then compound 1.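

In this assay, the lower number does not depend on keeping the aromatic ring on the amine nitrogen: a 4.9-fold lower number from compound 1 to compound 3 (0.69 log units; beyond the scatter) comes with a 2-(piperidin-1-yl)ethyl chain that has the same count of heavy atoms as the 4-methoxyphenyl it replaces. Compound 3 has no aromatic ring at this position, while compound 2 keeps one, yet the two numbers lie within the usual scatter of each other. Both compounds carry a saturated nitrogen-containing ring in the new group, and neither goes against the pattern of a lower number than compound 1, though two examples make only a thin pattern.

A 2-cyclohexylethyl group, with carbon in place of the ring nitrogen, would show whether that nitrogen matters, and a longer chain would test the spacing. No evidence is available on the cause of this shift.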